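The compounds below may be only part of what the source reports. "The series", "measured", "known", "first", "only" and "open" are said of these compounds alone.

Of the compounds shown here, three built on one shared core have been tested in a functional assay on HepG2 cells (Homo sapiens) for antiproliferative activity, read by MTT assay; a lower number here means a stronger inhibitor, a higher number a weaker inhibitor. Compound 1 `COc1cc2ncnc(NCc3cccc(NC(=O)Nc4cccc(C)c4)c3)c2cc1OC` gives 21500 nM. Compound 3 `COc1cc2ncnc(NCc3cccc(NC(=O)Nc4ccc(F)cc4)c3)c2cc1OC` gives 36600 nM, the higher of the two numbers shown, although the step of a 1.7-fold higher number from compound 1 to compound 3 (0.23 log units; within the scatter) stays within the scatter. For compound 2 `COc1ccc(NC(=O)Nc2cccc(CNc3ncnc4cc(OC)c(OC)cc34)c2)cc1` the assay reports only a limit, > 50000 nM. The step of an at least 2.3-fold higher number from compound 1 to compound 2 (0.36 log units; beyond the scatter) places compound 2 beyond the scatter, and the step of an at least 1.3-fold lower number from compound 2 to compound 3 (0.13 log units; that floor lies within the scatter) returns compound 3 to a number.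

Compound 4 `COc1cc2ncnc(NCc3cccc(NC(=O)Nc4cccc(C(F)(F)F)c4)c3)c2cc1OC` has not yet been measured. Compared with compound 3, (3-(trifluoromethyl)phenyl in place of 4-fluorophenyl on an amide-type nitrogen). The measured steps that bear on this are the two earlier swaps of the aryl group on the same nitrogen: a 1.7-fold higher number from compound 1 to compound 3 (0.23 log units; within the scatter) was small, and an at least 2.3-fold higher number from compound 1 to compound 2 (0.36 log units; beyond the scatter) was at least modest. Compound 1, which carries 3-methylphenyl at this place, gives 21500 nM. The expected step of a 1.2-fold lower number from compound 3 to compound 4 (0.09 log units; within the scatter) in this assay is therefore small, leaning if anything toward a lower number, and is not expected to reach beyond the scatter. Compound 4 is estimated at 30000 nM, with a range from 12000 nM to 70000 nM.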

Compound 4, half-maximal inhibitory concentration: 34200 nM
Beside the measured number, compound 4's estimate is 1.1-fold (0.06 log units) below it, within the range that was stated.
By their numbers in this assay, from the lowest: compounds 1, 4 and 3 (each within the scatter of the next). At a limit, above all of these: compound 2.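

In this assay, the step of a 1.1-fold lower number from compound 3 to compound 4 (0.03 log units; within the scatter) shows that replacing 4-fluorophenyl with 3-(trifluoromethyl)phenyl on the amide-type nitrogen, a swap that brings a larger group by heavy-atom count, leaves the number within the scatter. Trifluoromethyl in place of methyl on an aromatic carbon, the step of a 1.6-fold higher number from compound 1 to compound 4 (0.20 log units; within the scatter), is also within the scatter, so the three aryl groups with measured numbers at this place cannot be told apart in this assay. The 4-methoxyphenyl group is the exception to this shared band, yet the step of an at least 1.4-fold lower number from compound 2 to compound 4 (0.16 log units; that floor lies within the scatter) gives only a floor, as the value it starts from is a limit: the limit of > 50000 nM in this assay, at which 1 of the 4 values shown sits.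

Going by these compounds, what sets 4-methoxyphenyl apart remains open: the methoxy group itself or its place on the ring, a question that 3-methoxyphenyl at this nitrogen could help to settle. Also open, on these data alone, is whether an amine or a carboxylic acid on this phenyl ring, or a longer chain in place of the ring, would shift the number beyond the scatter in either direction.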